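This account rests on a few compounds, and the source may have more. Where it says the series, first, only, none or still open, it means among the compounds named here.

Working notes on the series. Compound 1 `CC1CC(C)(C)CC(O)(c2nnc(-c3ccccc3)[nH]2)C1` and compound 2 `CC1CC(C)(C)CC(O)(c2nnc(-c3ccncc3)[nH]2)C1` share one core; compound 3 `OC(c1nnc(-c2ccccc2)[nH]1)C1CC=CCC1` and compound 4 `OC(c1nnc(-c2ccncc2)[nH]1)C1CC=CCC1` share another. The difference between the two cores is not broken down here.

In an ADME assay on Vero cells (Chlorocebus sabaeus) for cytotoxicity, read by MTT assay, with a stated time of 72 h (on this read-out lower numbers stand for higher toxicity in this test and higher numbers for lower toxicity in this test), compound 1 gives 383 ug/mL. In this assay compound 2 gives 414 ug/mL. The change from compound 1 to compound 2 is pyridin-4-yl in place of phenyl on an aromatic carbon and the measured step was a 1.1-fold higher number from compound 1 to compound 2 (0.03 log units; within the scatter). In this assay compound 3 gives 358 ug/mL; set beside compound 1 and compound 2, all three numbers lie within the scatter of one another, so no order among them can be read from these data.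

Compound 4 arises from compound 3 by pyridin-4-yl in place of phenyl on an aromatic carbon. This is the same kind of change as that from compound 1 to compound 2, and it occurs twice among the compounds shown, once measured and once pending. The descriptions of the place agree word for word except that in the earlier pair the ring atom is said to bear a large group, whereas in the present pair it is said to bear a group of 8 heavy atoms.

The step from compound 3 to compound 4 in this assay is expected to be a 1.1-fold higher number from compound 3 to compound 4 (0.03 log units; within the scatter), beside the earlier 1.1-fold higher number from compound 1 to compound 2 (0.03 log units; within the scatter), resting on that single measured step having stayed within the scatter. Compound 4 is accordingly estimated at 380 ug/mL in this assay, with an expected range from 250 ug/mL to 560 ug/mL.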

Compound 4, half-maximal cytotoxic concentration: 388 ug/mL
For compound 4 the middle estimate is 1.0-fold (0.01 log units) below the measured one, within the range that was stated.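

In this assay the change to pyridin-4-yl in place of phenyl on an aromatic carbon gives a 1.1-fold higher number from compound 3 to compound 4 (0.03 log units; within the scatter), so on the core of compound 3 it leaves the read-out within the scatter. Set beside the step on the core of compound 1, the change carries from one core to the other with no difference that can be read: the same change on two cores in this assay, a 1.1-fold higher number (0.03 log units; within the scatter) from compound 1 to compound 2 and a 1.1-fold higher number (0.03 log units; within the scatter) from compound 3 to compound 4, 1.0-fold (0.00 log units) apart, within the scatter of two such steps. Among these compounds, this shows only that two steps, each within the scatter, agree in this assay; as neither step departs from the scatter, the agreement is one of two null results, and it does not show that the change would behave alike on a third core or in any other test, nor does it give a reason for the result.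

The compounds shown leave open whether a different group on that aromatic carbon of the five-membered aromatic ring, such as an amine, a carboxylic acid or a longer chain, would give a step beyond the scatter in this assay. They also leave open what each part of the difference between the two cores contributes, as compounds on these cores differ in more than one place.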